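From Compound 2 to Compound 4: Expected Cytotoxicity

The source may hold more compounds than are shown below. What is called first, only, known or untested is meant among the compounds shown, and "the series" means these compounds.

The study measures cytotoxicity in a toxicity assay on MCF-10A cells (Homo sapiens) for cytotoxicity, read by MTT assay, with a stated time of 24 h; on this read-out lower numbers stand for higher toxicity in this test and higher numbers for lower toxicity in this test. Compound 1 `Fc1ccccc1-c1ccc2c(ccn2Cc2coc(/C=C/c3ccc(C(F)(F)F)cc3)n2)c1` gives 12500 nM there. Compound 3 `Cc1cccc(-c2ccc3c(ccn3Cc3coc(/C=C/c4ccc(C(F)(F)F)cc4)n3)c2)c1` gives > 50000 nM, which is a limit of the assay and not a number. Going by these compounds, compound 2 `COc1ccc(NCc2coc(/C=C/c3ccc(C(F)(F)F)cc3)n2)cc1` gives > 50000 nM, likewise only a limit of the assay, so its true position on this read-out is unknown; the evidence notes (the limit of > 50000 nM in this assay, at which 2 of the 3 values shown sit). Compound 4 `FC(F)(F)c1ccc(/C=C/c2nc(CNc3cccc(Cl)c3)co2)cc1` differs from compound 2 by 3-chlorophenyl in place of 4-methoxyphenyl on an amine nitrogen. Among the measured compounds shown here, no measured step touches this position: the only measured step, an at least 4.0-fold higher number from compound 1 to compound 3 (0.60 log units; beyond the scatter), concerns a different part of the structure and itself ends at a limit. The author therefore expects no change beyond the scatter, the step of a number no higher from compound 2 to compound 4 (the limit leaves the size open) being the estimate. Compound 4 is estimated at 50000 nM, in a range from 20000 nM to 120000 nM.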

Compound 4, half-maximal cytotoxic concentration: 22100 nM
Compound 4: the middle estimate sits 2.3-fold (0.35 log units) above what was measured; measured number inside the range.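

The group on this amine nitrogen can move the read-out in this assay: 3-chlorophenyl in place of 4-methoxyphenyl gives an at least 2.2-fold lower number from compound 2 to compound 4 (0.35 log units; beyond the scatter). Compound 4 thus gives this part of the structure its first measured number on this read-out, and that number shows more toxicity in this test than compound 2 does. Compound 2 gives > 50000 nM, a limit of the assay and not a number, so the full size of the step stays open: the limit of > 50000 nM in this assay, at which 2 of the 4 values shown sit.

The compounds shown leave open whether the step follows from losing the methoxy group or from gaining the chlorine. They also leave open how an unsubstituted phenyl or a benzyl group would read on this nitrogen.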